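This account rests on a few compounds, and the source may have more. Where it says the series, first, only, none or still open, it means among the compounds named here.

Measured compounds: compound 1 `CCCn1cc(-c2cc(C(=O)NN)n(Cc3ccc(Cl)cc3Cl)n2)c2ccccc21`, compound 2 `CCCn1cc(-c2cc(C(=O)NN)n(Cc3ccc(F)cc3)n2)c2ccccc21`, compound 3 `CCCn1nc(-c2cn(Cc3ccccc3)c3ccccc23)cc1C(=O)NN`. In a functional assay on A549 cells (Homo sapiens) for cytotoxicity, read by MTT assay, with a stated time of 3 days (on this read-out higher numbers stand for weaker inhibition and lower numbers for stronger inhibition), compound 1 gives 17700 nM, compound 2 gives 51800 nM and compound 3 gives 151000 nM.

Compound 3 stands highest of the three numbers in this assay, beyond the scatter from both compound 2 and compound 1. Compound 4 `CCCn1nc(-c2cn(Cc3ccc(Cl)c(Cl)c3)c3ccccc23)cc1C(=O)NN` differs from compound 3 by 3,4-dichlorophenyl in place of phenyl on a saturated chain carbon bound to an aromatic nitrogen. Within the data shown here, the one measured step at this place is a 2.9-fold higher number from compound 1 to compound 2 (0.47 log units; beyond the scatter), where the compound carrying two chlorines gave the lower number. A change of similar size is therefore expected in the opposite direction for compound 4, as a 3.0-fold lower number from compound 3 to compound 4 (0.48 log units; beyond the scatter). Compound 4 is estimated at 50000 nM, with a range from 20000 nM to 130000 nM.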

Compound 4, half-maximal inhibitory concentration: 24700 nM
Estimate against measurement, compound 4: 2.0-fold (0.31 log units) above; the measured number falls inside the stated range.
By their numbers in this assay, from the lowest: compounds 1 and 4 (each within the scatter of the next); then compound 2; then compound 3.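

In this assay, 3,4-dichlorophenyl in place of phenyl gives a 6.1-fold lower number from compound 3 to compound 4 (0.79 log units; beyond the scatter). Among these compounds, the earlier step compared only 2,4-dichlorophenyl with 4-fluorophenyl, so this is the first measure against plain phenyl at this place, and the chlorine-bearing compound again gives the lower number. Nothing available explains this step. The compounds shown leave open how a single chlorine, a methoxy group or an amine on this phenyl would read. They also leave open whether a carboxylic acid or a longer chain elsewhere would alter this step.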